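Series notes: methyl for isopropyl at the chain carbon

This account rests on a few compounds, and the source may have more. Where it says the series, first, only, none or still open, it means among the compounds named here.

Measured so far in a functional assay on DU-145 cells (Homo sapiens) for cytotoxicity, read by MTT assay; a higher number here means a weaker inhibitor, a lower number a stronger inhibitor:
compound 1 `CC(C)[C@H](NC(=S)Nc1ccccc1)c1nc2ccccc2[nH]1` gives 12300 nM;
compound 2 `CC(C)[C@@H](NC(=S)NCc1ccccc1)c1nc2ccccc2[nH]1` gives 17300 nM;
compound 3 `CC(C)[C@@H](NC(=S)Nc1ccccc1)c1nc2ccccc2[nH]1` gives 34800 nM.

Compound 3 has the highest of the three numbers. Its nearest neighbour is compound 2, with a 2.0-fold higher number from compound 2 to compound 3 (0.30 log units; within the scatter); compound 1 lies further off, with a 2.8-fold higher number from compound 1 to compound 3 (0.45 log units; beyond the scatter), the latter pair being separated only by the fact that compounds 1 and 3 differ only in the configuration as drawn.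

Compound 4 `C[C@@H](NC(=S)Nc1ccccc1)c1nc2ccccc2[nH]1` carries the change (methyl in place of isopropyl on a saturated chain carbon bound to an amide-type nitrogen and an aromatic carbon). Neither measured step touches the substituent on that chain carbon: one changes configuration, the other the group on the amide-type nitrogen. Going by the values given here, no measured step therefore bears directly on this change, and both known steps were small. The expectation is no step beyond the scatter, a 1.0-fold higher number from compound 3 to compound 4 (0.00 log units; within the scatter). Compound 4 is estimated at 35000 nM, with a range of 12000 nM to 100000 nM.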

Compound 4, half-maximal inhibitory concentration: 22100 nM
Beside the measured number, compound 4's estimate is 1.6-fold (0.20 log units) above it; measured number inside the range.
By their numbers in this assay, from the lowest: compounds 1, 2, 4 and 3 (each within the scatter of the next, the first and the last beyond it).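

In this assay, methyl in place of isopropyl on the saturated chain carbon bound to an amide-type nitrogen and an aromatic carbon gives a 1.6-fold lower number from compound 3 to compound 4 (0.20 log units; within the scatter). Going by these compounds alone, this is the first reading at this position, and with the configuration of compound 3 kept, the exchange stays within the scatter, so isopropyl is not needed to hold the number there. Nothing at hand accounts for the size of this step.

As far as these compounds go, it stays open whether the same exchange reads alike in the configuration of compound 1. From the compounds shown here alone, what a longer chain, a phenyl ring or an amine would give on that chain carbon also stays open.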